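Capping the phenol of a cinnamamide with a trimethoxyphenyl group

A few compounds are considered here, and "the series" means these few. Any claim that something is new, unique, unknown or untested is made for them only; others in the source may bear on it.

Compound 1 `COc1cc(CNC(=O)/C=C/c2ccc(O)cc2)ccc1OCc1nc(C)c(C)nc1C` gives 3740 nM in a functional assay on SH-SY5Y cells (Homo sapiens) for cytotoxicity, read by MTT assay, with stated times of 24 h and 4 h (a lower number here means that less compound is needed, a higher number that more compound is needed for the effect), the lowest of the three numbers recorded. Among the measured compounds shown here, compound 2 `COc1cc(CNC(=O)/C=C/c2ccc(OCc3nc(C)c(C)nc3C)cc2)ccc1OCc1nc(C)c(C)nc1C` gives 7770 nM, and the one measured step, a 2.1-fold higher number from compound 1 to compound 2 (0.32 log units; beyond the scatter), replaces the phenol hydrogen of compound 1. Compound 3 `COc1cc(/C=C/C(=O)NCc2ccc(O)c(OC)c2)cc(OC)c1` gives 4860 nM, which lies within the scatter of compound 1, so no order between them can be claimed. Compound 4 `COc1cc(CNC(=O)/C=C/c2cc(OC)c(OC)c(OC)c2)ccc1OCc1nc(C)c(C)nc1C` differs from compound 1 in that (3,4,5-trimethoxyphenyl in place of 4-hydroxyphenyl on a double-bonded chain carbon bound to a double-bonded chain carbon). That change also removes the phenol hydrogen, the only loss shared with the step from compound 1 to compound 2, so a modest rise in the number is expected, a 1.7-fold higher number from compound 1 to compound 4 (0.24 log units; within the scatter). Compound 4 is therefore estimated at 6500 nM, with a range from 2800 nM to 15000 nM.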

Compound 4, half-maximal effective concentration: 11500 nM
Beside the measured number, compound 4's estimate is 1.8-fold (0.25 log units) below it; the range from low to high includes it.
By their numbers in this assay, from the lowest: compounds 1, 3, 2 and 4 (each within the scatter of the next, the first and the last beyond it).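

In this assay, 3,4,5-trimethoxyphenyl in place of 4-hydroxyphenyl gives a 3.1-fold higher number from compound 1 to compound 4 (0.49 log units; beyond the scatter). Together with the step to compound 2, this makes two changes at the phenol end of compound 1 that remove the phenol hydrogen, and both raise the number. No measurement offered here explains the rise.

The shown compounds cannot separate the lost phenol hydrogen from the added methoxy groups. A 4-methoxyphenyl group would test the first alone, while a 4-aminophenyl group would show whether another hydrogen-bearing group can stand in for the hydroxyl.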